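Naphthyl for fluorophenyl in the macrolactone series

This account rests on a few compounds, and the source may have more. Where it says the series, first, only, none or still open, it means among the compounds named here.

Values in a functional assay on A-375 cells (Homo sapiens) for inhibition, read by MTT assay, with a stated time of 48 h (a lower number here means a stronger inhibitor, a higher number a weaker inhibitor), for the compounds measured so far:
- compound 1 (`C[C@H]1CCC/C=C/[C@H]2CC[C@H](O)[C@H](CC(=O)O1)O2`) gives "not determined" (no result reported) (no number)
- compound 2 (`CCO[C@H]1C=C[C@H]2C/C=C\CC[C@H](C)OC(=O)C[C@@H]1O2`) gives 57000 nM (ethyl ether)
- compound 3 (`COc1ccc(CO[C@H]2C=C[C@H]3C/C=C\C[C@H](c4ccc(F)cc4)OC(=O)C[C@@H]2O3)cc1`) gives 4760 nM (4-fluorophenyl)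

Compound 3 at 4760 nM holds the lower of the two numbers, and compound 2 at 57000 nM sits higher by a gap beyond the scatter. These two compounds differ in more than one place, so the gap cannot be tied to a single group.

Compound 4 (`COc1ccc(CO[C@H]2C=C[C@H]3C/C=C\C[C@H](c4ccc5ccccc5c4)OC(=O)C[C@@H]2O3)cc1`) has naphthalen-2-yl in place of 4-fluorophenyl on a saturated ring carbon, next to the ring oxygen: naphthalen-2-yl in place of 4-fluorophenyl on a saturated ring carbon is the whole change. Among the compounds with values here, no measured pair tests this position, so the expectation starts from compound 3 at 4760 nM and stays cautious. The expected step of a 1.4-fold lower number from compound 3 to compound 4 (0.13 log units; within the scatter) is no larger than the scatter and leans slightly toward a lower number. In this assay the estimate for compound 4 is 3500 nM with an expected range from 1200 nM to 11000 nM (estimated)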

Compound 4, half-maximal inhibitory concentration: > 100000 nM
Compound 4 ended at the assay's limit (the forecaster's own chance of this, stated with the estimate: 5%); middle value at least 28-fold (1.45 log units) away from the limit.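

In this assay compound 4 gives > 100000 nM, which is a limit of the assay and not a number. Even so, naphthalen-2-yl in place of 4-fluorophenyl on a saturated ring carbon, next to the ring oxygen, reads as an at least 21-fold higher number from compound 3 to compound 4 (1.32 log units; beyond the scatter), the first step in the series that changes only one place, and it shows that the readout at this position depends on the group it carries. The full size of the step cannot be read, as compound 4 sits at the end of the measurable range: the limit of > 100000 nM in this assay, at which 1 of the 4 values shown sits.

With only these two groups compared at this carbon, the compounds shown do not separate the effect of the second six-membered aromatic ring from that of losing the fluorine. On these data alone, how a plain phenyl or a 4-aminophenyl group would read at this carbon in this assay also remains open.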